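Compound 3 to compound 4: an amino-linked aryl group

The source may report more compounds than this note shows. Statements on the series, on what has been measured and on what is new or still open speak of the compounds shown alone.

Measured in a functional assay on HL-60 cells (Homo sapiens) for antiproliferative activity, read by MTT assay, with a stated time of 72 h; a higher number here means a weaker inhibitor, a lower number a stronger inhibitor:
- compound 1 `COc1cc(C(=O)c2sc3ccccc3c2-c2ccccc2)cc(OC)c1OC`: 1700 nM
- compound 2 `COc1ccc(-c2c(C(=O)c3cc(OC)c(OC)c(OC)c3)sc3ccccc23)c(OC)c1`: 4600 nM
- compound 3 `COc1ccc(-c2c(C(=O)c3cc(OC)c(OC)c(OC)c3)sc3ccccc23)cc1C`: > 10000 nM

The reading for compound 3 is a limit of the assay and not a number. Its steps from the other two place compound 3 as the weakest of the three. Compound 4 `COc1ccc(Nc2c(C(=O)c3cc(OC)c(OC)c(OC)c3)sc3ccccc23)cc1` carries (4-methoxyphenyl)amino in place of 4-methoxy-3-methylphenyl on an aromatic carbon.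

Three measured steps change the group at this place. They are a 2.7-fold higher number from compound 1 to compound 2 (0.43 log units; beyond the scatter), then an at least 5.8-fold higher number from compound 1 to compound 3 (0.76 log units; beyond the scatter), and finally an at least 2.1-fold higher number from compound 2 to compound 3 (0.33 log units; beyond the scatter). All are modest or at least modest in size, and none introduces an amino link, so they bear on the new step only indirectly. With compound 2 at 4600 nM, a modest move to a lower number in this assay is expected. A further limit reading remains possible. The expected change is an at least 3.3-fold lower number from compound 3 to compound 4 (0.52 log units; beyond the scatter). For compound 4 the estimated value is 3000 nM, with an expected range of 500 nM to 10000 nM.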

Compound 4, half-maximal inhibitory concentration: 3700 nM
Estimate against measurement, compound 4: 1.2-fold (0.09 log units) below, within the range that was stated.
By their numbers in this assay, from the lowest: compound 1; then compounds 4 and 2 (each within the scatter of the next). At a limit, above all of these: compound 3.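

In this assay, (4-methoxyphenyl)amino in place of 4-methoxy-3-methylphenyl gives an at least 2.7-fold lower number from compound 3 to compound 4 (0.43 log units; beyond the scatter), so an aryl group held through an amino link is compatible with activity at this position. Against the 2,4-dimethoxyphenyl group, the amino-linked group gives a 1.2-fold lower number from compound 2 to compound 4 (0.09 log units; within the scatter), while the plain phenyl group still gives the lower number, with a 2.2-fold higher number from compound 1 to compound 4 (0.34 log units; beyond the scatter). Compound 3 stands at a limit of the assay and not at a number, so its step gives only a lower bound on the change: the limit of > 10000 nM in this assay, at which 1 of the 4 values shown sits.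

What the amino link does by itself stays open, as every pair shown changes the aryl group along with it. A phenylamino group would set the link directly against the phenyl group, and a 4-methoxyphenyl group joined directly or through an ether oxygen would do the same for the (4-methoxyphenyl)amino group.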